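This account rests on a few compounds, and the source may have more. Where it says the series, first, only, none or still open, it means among the compounds named here.

Measured compounds:
- compound 1 `COc1cc2c(Oc3ccc(NC(=O)c4nn(-c5ccccc5C)c(=O)cc4C)cc3F)ccnc2cc1OCCCN1CCC(C)CC1`: 1460 nM
- compound 2 `COc1ccc(-n2nc(C(=O)Nc3ccc(Oc4ccnc5cc(OCCCN6CCCC6)c(OC)cc45)c(F)c3)c(C)cc2=O)cc1`: 2770 nM

Among the compounds with values here, in a functional assay on A549 cells (Homo sapiens) for inhibition, read by MTT assay, with a stated time of 72 h (on this read-out lower numbers stand for stronger inhibition and higher numbers for weaker inhibition), compound 2 gives 2770 nM, the higher of the two numbers so far, and in this assay compound 1 gives 1460 nM; the gap between the two lies within the scatter, so nothing can be said about their order. Within the data shown here, no step between measured compounds that differ in one place is available, since compound 1 and compound 2 differ from each other in more than one place.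

Compound 3 `COc1ccc(-n2nc(C(=O)Nc3ccc(Oc4ccnc5cc(OCCCN6CCC(C)CC6)c(OC)cc45)c(F)c3)c(C)cc2=O)cc1` has not been measured. It arises from compound 2 by the change (4-methylpiperidin-1-yl in place of pyrrolidin-1-yl on a saturated chain carbon, three bonds along the chain from an oxygen on an aromatic ring); the rest of the molecule is kept. The 4-methylpiperidin-1-yl group that enters is also carried by compound 1. On the numbers shown, only a small step is expected from compound 2 to compound 3, with no clear direction beyond the scatter, and the estimated step is a 1.4-fold lower number from compound 2 to compound 3 (0.14 log units; within the scatter). Compound 3 is therefore expected to give about 2000 nM in this assay, with a range from 700 nM to 5500 nM.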

Compound 3, half-maximal inhibitory concentration: 1100 nM
Compound 3: middle estimate off by 1.8-fold (0.26 log units), on the high side; the measured number falls inside the stated range.
By their numbers in this assay, from the lowest: compounds 3, 1 and 2 (each within the scatter of the next, the first and the last beyond it).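

In this assay the exchange on the saturated chain carbon, three bonds along the chain from an oxygen on an aromatic ring, now has its first one-place reading: 4-methylpiperidin-1-yl in place of pyrrolidin-1-yl gives a 2.5-fold lower number from compound 2 to compound 3 (0.40 log units; beyond the scatter) with the 4-methoxyphenyl group on the aromatic nitrogen kept. The second new pair reads the aromatic nitrogen with 4-methylpiperidin-1-yl kept, and there 4-methoxyphenyl in place of 2-methylphenyl gives a 1.3-fold lower number from compound 1 to compound 3 (0.12 log units; within the scatter) so this change sets no order between the two compounds in this assay. Nothing given here offers a reason for either step.

The compounds shown cannot separate the six-membered ring from its methyl group, as neither a plain piperidin-1-yl nor a morpholin-4-yl stands among them. Also open, as far as these compounds go, is whether the step carries over to compounds with 2-methylphenyl on the aromatic nitrogen, and whether it holds on a shorter chain such as 2-(4-methylpiperidin-1-yl)ethyl in place of 3-(4-methylpiperidin-1-yl)propyl.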